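Opening the ring at the sulfur-bound carbon

The source may report more compounds than this note shows. Statements on the series, on what has been measured and on what is new or still open speak of the compounds shown alone.

Compound 1 `O=C1CC(O)CC(CSc2nc(-c3ccccc3)c(-c3ccccc3)[nH]2)O1` gives 910 nM in an assay on microsomes from liver for inhibition of sterol O-acyltransferase 1 (Rattus norvegicus); a lower number here means a stronger inhibitor, a higher number a weaker inhibitor.
Compound 2 `CC1(C)CC(=O)OC(CSc2nc(-c3ccccc3)c(-c3ccccc3)[nH]2)C1` gives 100 nM in this assay.
Compound 3 `c1ccc(-c2nc(SCC3OCCCO3)[nH]c2-c2ccccc2)cc1` gives 180 nM in this assay.

Compound 3 stands second highest of the three numbers. Its nearest neighbour is compound 2, the pair being separated by a 1.8-fold higher number from compound 2 to compound 3 (0.26 log units; within the scatter). Its furthest neighbour is compound 1, seen in a 5.1-fold lower number from compound 1 to compound 3 (0.70 log units; beyond the scatter).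

Compound 4 `CCOC(CCSc1nc(-c2ccccc2)c(-c2ccccc2)[nH]1)OCC` differs from compound 3 in one place: a group of 8 heavy atoms (6 carbon, 2 oxygen; no ring) in place of a group of 6 heavy atoms (4 carbon, 2 oxygen; one six-membered non-aromatic ring with 2 hetero atoms), on a saturated chain carbon bound to a sulfur. All three measured steps change the group on that same saturated chain carbon bound to a sulfur, so all three bear on this change. Two of them were modest and beyond the scatter, a 9.1-fold lower number from compound 1 to compound 2 (0.96 log units; beyond the scatter) and a 5.1-fold lower number from compound 1 to compound 3 (0.70 log units; beyond the scatter), while the third, a 1.8-fold higher number from compound 2 to compound 3 (0.26 log units; within the scatter), stayed within it. Within the data shown here, no measured step, however, trades a ring for an open chain, so there is no direct precedent for the kind of change that leads to compound 4. Taking the three steps together, the group at this position has moved this assay by at most a modest amount, and compound 4 is expected to sit close to compound 3, with a step of about a 1.2-fold higher number from compound 3 to compound 4 (0.09 log units; within the scatter) that may well fall within the scatter. For compound 4 the estimated value is 220 nM, with a range of 70 nM to 700 nM.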

Compound 4, half-maximal inhibitory concentration: 69 nM
Estimate against measurement, compound 4: 3.2-fold (0.50 log units) above; measured number below the stated range.
By their numbers in this assay, from the lowest: compounds 4, 2 and 3 (each within the scatter of the next, the first and the last beyond it); then compound 1.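

Opening the ring did not weaken inhibition in this assay: the change to the 2,2-diethoxyethyl group gives a 2.6-fold lower number from compound 3 to compound 4 (0.42 log units; beyond the scatter), so among these compounds a ring on the saturated chain carbon bound to a sulfur is not required for a number in this range, and the open chain gives the better result of this pair. The open chain also cannot be told apart from the ring of compound 2, with a 1.4-fold lower number from compound 2 to compound 4 (0.16 log units; within the scatter), which shows that two quite different groups, one cyclic and one acyclic, can give equivalent numbers here. Among these compounds, the group of compound 1 now stands further apart from the rest, with a 13-fold lower number from compound 1 to compound 4 (1.12 log units; beyond the scatter), the only large step in the set, and compounds 2, 3 and 4 all have numbers beyond the scatter below that of compound 1.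

From the compounds shown here alone, what an amine, a carboxylic acid or a longer chain in place of the 2,2-diethoxyethyl group would do remains open. The data shown also offer no measurement that accounts for the lower number of the open chain relative to the ring of compound 3.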